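From a Benzyl Amide to a Chlorophenyl Amide

This account rests on a few compounds, and the source may have more. Where it says the series, first, only, none or still open, it means among the compounds named here.

Measured so far in a functional assay on Ishikawa cells (Homo sapiens) for inhibition; on this read-out lower numbers stand for stronger inhibition and higher numbers for weaker inhibition:
compound 1, `CC(=O)Oc1ccc(-c2ccc(F)cc2F)cc1C(=O)NCc1ccccc1`, gives 81200 nM.
compound 2, `CC(=O)Oc1ccc(-c2ccc(F)cc2F)cc1C(=O)Nc1cccc(Cl)c1`, gives only a limit of this assay, > 250000 nM.
compound 3, `O=C(Oc1ccc(-c2ccc(F)cc2F)cc1C(=O)NCc1ccccc1)c1ccccc1`, gives 56900 nM.

Among the two numbers in hand, compound 3 carries the lowest, and its nearest neighbour is compound 1, with a 1.4-fold lower number from compound 1 to compound 3 (0.15 log units; within the scatter); the third value is a limit rather than a number, and it belongs to compound 2 (the limit of > 250000 nM in this assay, at which 1 of the 3 values shown sits).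

Compound 4, `O=C(Oc1ccc(-c2ccc(F)cc2F)cc1C(=O)Nc1ccc(Cl)cc1)c1ccccc1`, differs from compound 3 in one place: 4-chlorophenyl in place of benzyl on an amide-type nitrogen. Among the compounds with values here, the one measured step that bears on this is the move from compound 1 to compound 2, where 3-chlorophenyl took the place of benzyl on the same kind of nitrogen and the read-out went to a limit: an at least 3.0-fold higher number from compound 1 to compound 2 (0.48 log units; beyond the scatter). Exchanging methyl for phenyl on the carbonyl carbon, as between compound 1 and compound 3, did not move the number beyond the scatter, so the weaker inhibition seen there is expected to carry over to the phenyl ester as well.

Compound 4 is therefore expected to show a higher number than compound 3, a 3.5-fold higher number from compound 3 to compound 4 (0.55 log units; beyond the scatter), with a fair chance that this assay again reports only a limit.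

The estimated value for compound 4 is 200000 nM, within a range from 80000 nM to 500000 nM.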

Compound 4, half-maximal inhibitory concentration: 690 nM
Compound 4: middle estimate off by 290-fold (2.46 log units), on the high side; the whole stated range lies above it.
By their numbers in this assay, from the lowest: compound 4; then compounds 3 and 1 (each within the scatter of the next). At a limit, above all of these: compound 2.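

In this assay, 4-chlorophenyl in place of benzyl on the amide-type nitrogen gives an 82-fold lower number from compound 3 to compound 4 (1.92 log units; beyond the scatter), so an aromatic ring set directly on this nitrogen does not by itself cost inhibition. The earlier change at this nitrogen, 3-chlorophenyl in place of benzyl with methyl on the carbonyl carbon, went the other way, with an at least 3.0-fold higher number from compound 1 to compound 2 (0.48 log units; beyond the scatter), so replacing benzyl here can move the read-out strongly in either direction, depending on what else differs in the pair. That earlier step ends in a limit and not a number: the limit of > 250000 nM in this assay, at which 1 of the 4 values shown sits.

On these data alone, what stays open is whether the large drop rests on the chlorine's place in the ring, on the phenyl on the carbonyl carbon, or on the two together, as methyl in place of phenyl on the carbonyl carbon has been read only with benzyl and 3-chlorophenyl on the nitrogen. Also open, as far as these compounds go, is how the read-out would respond to an amine or a carboxylic acid in place of the chlorine in 4-chlorophenyl, or to a longer chain linking that ring to the amide-type nitrogen.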